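Dodecyl sulfonylurea series: chain extension to hexadecyl

The compounds below may be only part of what the source reports. "The series", "measured", "known", "first", "only" and "open" are said of these compounds alone.

Measured so far in an assay on microsomes from intestine for inhibition of acyl-CoA:cholesterol acyltransferase (Oryctolagus cuniculus); on this read-out lower numbers stand for stronger inhibition and higher numbers for weaker inhibition:
compound 1 `CCCCCCCCCCCCS(=O)(=O)NC(=O)Nc1c(C(C)C)cccc1C(C)C` — 2330 nM
compound 2 `CCCCCCCCCCCCS(=O)(=O)N(C)C(=O)Nc1c(C(C)C)cccc1C(C)C` — 86 nM
compound 3 `CCCCCCCCCCCCCC(c1ccccc1)S(=O)(=O)NC(=O)Nc1c(C(C)C)cccc1C(C)C` — 2000 nM

Compound 1 has the highest number of the three. Compound 3, which carries a phenyl on the chain carbon next to the sulfonyl and a longer chain, gives 2000 nM, within the scatter of the number for compound 1. Going by the values given here, compound 2 stands far apart: the only measured step, a 27-fold lower number from compound 1 to compound 2 (1.43 log units; beyond the scatter), comes from a methyl in place of hydrogen on an amide-type nitrogen.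

Compound 4 `CCCCCCCCCCCCCCCCS(=O)(=O)NC(=O)Nc1c(C(C)C)cccc1C(C)C` differs from compound 1 by butyl in place of hydrogen on a saturated chain carbon, ten or more bonds along the chain from a sulfonyl sulfur — the dodecyl chain becomes hexadecyl, while the sulfonylurea and the shared core are kept. Among the compounds with values here, no measured step covers this change. The methyl step from compound 1 to compound 2 concerns the nitrogen and does not bear on it. Within the data shown here, the only hint comes from compound 1 and compound 3, whose numbers show that reshaping the chain end near the sulfonyl leaves this assay's number within the scatter.

Compound 4 is therefore expected to change little, with an estimated step of a 1.3-fold lower number from compound 1 to compound 4 (0.11 log units; within the scatter). The estimate for compound 4 in this assay is 1800 nM, between 600 nM and 5500 nM.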

Compound 4, half-maximal inhibitory concentration: 1350 nM
For compound 4 the middle estimate is 1.3-fold (0.12 log units) above the measured one, and the stated range covers the measured number.
By their numbers in this assay, from the lowest: compound 2; then compounds 4, 3 and 1 (each within the scatter of the next).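

In this assay, butyl in place of hydrogen on a saturated chain carbon, ten or more bonds along the chain from a sulfonyl sulfur, gives a 1.7-fold lower number from compound 1 to compound 4 (0.24 log units; within the scatter), so going from dodecyl to hexadecyl is a step that stays within the scatter. The earlier compounds shown here held no step at this position, and this reading sets the chain change apart from the methyl on the amide-type nitrogen, where the step is a 27-fold lower number from compound 1 to compound 2 (1.43 log units; beyond the scatter) and lies beyond the scatter. No supporting data bear on the reason for this result.

The compounds shown leave open whether the hexadecyl chain would also stay within the scatter when combined with the methyl on the amide-type nitrogen of compound 2, whose number is the only one that stands apart in the series. Also open, on these data alone, is how a still longer chain, or a carboxylic acid or an amine at the far end of the chain, would read against compound 1 in this assay.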